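The source may report more compounds than this note shows. Statements on the series, on what has been measured and on what is new or still open speak of the compounds shown alone.

Measured compounds:
compound 1, `Brc1ccc2[nH]cc(C(c3ccccc3)c3c[nH]c4ccc(Br)cc34)c2c1`, 7500 nM
compound 2, `COc1ccc(C(c2c[nH]c3ccc(Br)cc23)c2c[nH]c3ccc(Br)cc23)cc1`, 10000 nM
compound 3, `Brc1ccc(C(c2c[nH]c3ccc(Br)cc23)c2c[nH]c3ccc(Br)cc23)cc1`, 5600 nM

In a functional assay on A549 cells (Homo sapiens) for inhibition, read by MTT assay, with a stated time of 48 h (a lower number here means a stronger inhibitor, a higher number a weaker inhibitor), compound 1 gives 7500 nM, compound 2 gives 10000 nM and compound 3 gives 5600 nM. Compound 2 stands apart from neither neighbour: the step of a 1.3-fold higher number from compound 1 to compound 2 (0.12 log units; within the scatter) and the step of a 1.8-fold lower number from compound 2 to compound 3 (0.25 log units; within the scatter) both lie within the scatter, as does the step of a 1.3-fold lower number from compound 1 to compound 3 (0.13 log units; within the scatter). The three compounds are thus indistinguishable in this assay.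

Compound 4, `CCCC(c1c[nH]c2ccc(Br)cc12)c1c[nH]c2ccc(Br)cc12`, is not yet measured. Its difference from compound 2 is propyl in place of 4-methoxyphenyl on a saturated chain carbon bound to two aromatic carbons. Within the data shown here, none of the measured steps bears on this change directly: each of them only exchanges a substituent on the aromatic ring that is now removed, and each stayed within the scatter. Those steps show only that the substituent on that ring did not matter; they say nothing about taking the ring away and putting a propyl in its place. Among the measured compounds shown here, with no step of this kind to lean on, the expected step of a 1.2-fold higher number from compound 2 to compound 4 (0.08 log units; within the scatter) is set near zero, with a wide range to allow for a change in either direction. Compound 4 is therefore estimated at 12000 nM, between 4000 nM and 40000 nM.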

Compound 4, half-maximal inhibitory concentration: 6500 nM
Compound 4: the middle estimate sits 1.8-fold (0.27 log units) above what was measured; the measured number falls inside the stated range.
By their numbers in this assay, from the lowest: compounds 3, 4, 1 and 2 (each within the scatter of the next).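

In this assay the aromatic ring on the saturated chain carbon bound to two aromatic carbons can be exchanged for propyl without leaving the scatter: the step of a 1.5-fold lower number from compound 2 to compound 4 (0.19 log units; within the scatter) and the step of a 1.2-fold higher number from compound 3 to compound 4 (0.06 log units; within the scatter) and the step of a 1.2-fold lower number from compound 1 to compound 4 (0.06 log units; within the scatter) all stay inside it. The earlier compounds shown here showed this only for substituents on that ring, whereas here the whole of 4-methoxyphenyl, 4-bromophenyl or phenyl gives way to a group with no ring and fewer heavy atoms, and the numbers of these four compounds cannot be told apart. No measurement at hand accounts for this result.

The compounds shown leave open whether a longer chain such as hexyl, or a chain ending in an amine or a carboxylic acid, would also stay within the scatter at this saturated chain carbon. All four compounds also carry the same bromo groups on the shared core, so they say nothing about how the number would respond to hydrogen or methoxy in their place.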